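The source may report more compounds than this note shows. Statements on the series, on what has been measured and on what is new or still open speak of the compounds shown alone.

Compound 1 (`NCCCCN(C[C@H]1Cc2cccnc2CN1)[C@H]1CCCc2cccnc21`) gives 6 nm/s in an ADME assay for permeability, using PAMPA, with a stated time of 4 h, at pH 7.4 (on this read-out lower numbers stand for lower permeability and higher numbers for higher permeability), and compound 2 (`NCCCCN(C[C@H]1Cc2nccnc2CN1)[C@H]1CCCc2cccnc21`) gives 2 nm/s there, the lower of the two numbers and beyond the scatter. Compound 3 (`NCCCCN(C[C@@H]1Cc2nccnc2CN1)[C@H]1CCCc2cccnc21`) stands to compound 2 as follows (the two compounds have the same atoms and bonds and differ only in configuration as drawn: 1 of 2 stereo elements differ; a stereocentre at a saturated ring carbon is drawn R in compound 2 and S in compound 3). Going by the values given here, no measured pair shows a change of this kind, so no step beyond the scatter is expected in this assay in either direction. The expected change is a 1.3-fold higher number from compound 2 to compound 3 (0.10 log units; within the scatter) and stays within the scatter. The estimate for compound 3 is 2.5 nm/s (expected range 1 nm/s to 6 nm/s).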

Compound 3, apparent permeability: 2 nm/s
Compound 3: the middle estimate sits 1.3-fold (0.10 log units) above what was measured; the range from low to high includes it.
By their numbers in this assay, from the lowest: compounds 2 and 3 (each within the scatter of the next); then compound 1.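

In this assay, inverting the stereocentre at a saturated ring carbon gives no change at the digits printed from compound 2 to compound 3 (within the scatter). Going by these compounds alone, this is the first pair to isolate this stereocentre, and with all else held constant, the drawn configuration leaves the read-out unmoved within the scatter. The reading rests on this single pair: the fact that compounds 2 and 3 differ only in the configuration as drawn

Going by these compounds, whether the same inversion behaves alike on the core of compound 1 stays open, as does the effect of inverting the other stereocentre. Also open, on these data alone, is what a carboxylic acid or a longer chain in place of the primary amine would give in this assay.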